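The source may report more compounds than this note shows. Statements on the series, on what has been measured and on what is new or still open speak of the compounds shown alone.

Of the compounds shown here, two have been measured in a functional assay on the whole organism (Tail, strain ICR) with Mus musculus as the target, in the tail flick test, with a stated time of 150 min, at a dose of 25 umol/kg by the oral route; a higher number here means a stronger effect of the compound at the dose given, a lower number a weaker effect. Compound 1 `O=C(CN(c1ncnc2c1ncn2C1CCCCO1)C1CC1)NCC(=O)OCc1ccccc1` gives 7.26%. Among the measured compounds shown here, compound 2 `CC[C@H](C)[C@H](NC(=O)CN(c1nc(Cl)nc2[nH]cnc12)C1CC1)C(=O)O` gives 6.71%, and the only other number, from compound 1, lies within the usual scatter of it, so the two compounds read as alike and both sit close to the bottom of the percentage scale. Compound 3 `NC(=O)C[C@H](NC(=O)CN(c1nc(Cl)nc2[nH]cnc12)C1CC1)C(=O)O` has not yet been measured. It differs from compound 2 in one place: carbamoylmethyl in place of sec-butyl on a saturated chain carbon bound to an amide-type nitrogen and a carbonyl carbon. For the measured compounds named here, no step between two measured compounds that differ in one place is available, so the effect of this change can only be judged from the level of the two numbers at hand. Going by the values given here, nothing measured so far suggests that this change would lift the read-out, and a value near the floor has little room to fall. The step from compound 2 to compound 3 is therefore expected to be small, not beyond the scatter, in either direction: a number 0.7 percentage points lower from compound 2 to compound 3 (within the scatter). For compound 3 the expected value is 6%, with a range from 0% to 16%.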

Compound 3, a percentage reported as activity, at one dose (the size of the read-out at that dose, not a potency): 7.51%
For compound 3 the middle estimate is 1.5 percentage points below the measured one; the range from low to high includes it.
By their numbers in this assay, from the lowest: compounds 2, 1 and 3 (each within the scatter of the next).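

In this assay, among the compounds shown here, putting carbamoylmethyl in place of sec-butyl on a saturated chain carbon bound to an amide-type nitrogen and a carbonyl carbon gives a number 0.8 percentage points higher from compound 2 to compound 3 (within the scatter), the first direct reading of a change in one place. The two groups have the same count of heavy atoms, yet only carbamoylmethyl brings a double bond, a hydrogen-bond donor and a hydrogen-bond acceptor, and this pair still reads alike, so at this dose and time the exchange leaves no visible mark on the effect in the tail. No measurement at hand bears on why the pair reads alike.

With both numbers close to the bottom of the scale, one pair at one dose cannot tell whether this position truly tolerates any group or whether the effect is simply too small to show a difference. Also open, as far as these compounds go, is whether a benzyl group or a 4-aminobutyl chain at the same place would move the read-out beyond the usual scatter.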